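This account rests on a few compounds, and the source may have more. Where it says the series, first, only, none or still open, it means among the compounds named here.

Measured in a functional assay on NCI-H661 cells (Homo sapiens) for antiproliferative activity, read by MTT assay, with a stated time of 72 h; a higher number here means a weaker inhibitor, a lower number a stronger inhibitor:
- compound 1 `O=C(CCCCCCc1nc(-c2cccs2)no1)NO`: 9460 nM
- compound 2 `Nc1ccccc1NC(=O)CCCCCCc1nc(-c2ccccc2)no1`: 960 nM

Compound 2 at 960 nM holds the lower of the two numbers, beyond the scatter from compound 1.

Compound 3 `Nc1ccccc1NC(=O)CCCCCCc1nc(-c2cccc([N+](=O)[O-])c2)no1` differs from compound 2 by nitro in place of hydrogen on an aromatic carbon, phenyl to 3-nitrophenyl. Among the measured compounds shown here, no measured pair shows this change, so the expectation has no direct precedent. In this assay the expected outcome is no step beyond the scatter, with a slight lean towards a higher number. The estimated step of a 1.3-fold higher number from compound 2 to compound 3 (0.10 log units; within the scatter) is small. For compound 3 the estimated value is 1200 nM, with an expected range of 350 nM to 3500 nM.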

Compound 3, half-maximal inhibitory concentration: 7290 nM
The estimate for compound 3 lay 6.1-fold (0.78 log units) below the measured number; measured number above the stated range.
By their numbers in this assay, from the lowest: compound 2; then compounds 3 and 1 (each within the scatter of the next).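

In this assay, among the compounds shown here, the change from phenyl to 3-nitrophenyl gives a 7.6-fold higher number from compound 2 to compound 3 (0.88 log units; beyond the scatter) in the first single-place comparison of the series. The aromatic ring carrying this substituent is therefore not indifferent to what is placed on it, at least for nitro at this carbon. Nothing at hand accounts for the step.

Going by these compounds, whether the step is specific to nitro stays open, as one substituent at one carbon cannot separate the group from the place. An amine or a methoxy group at the same carbon would help to test this.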